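Swapping the halogenated phenyl on a thiocarbamate-linked triazole

The source may report more compounds than this note shows. Statements on the series, on what has been measured and on what is new or still open speak of the compounds shown alone.

Of the compounds shown here, three have been measured in a functional assay on PC-3 cells (Homo sapiens) for cytotoxicity, read by MTT assay, with a stated time of 24 h (on this read-out lower numbers stand for stronger inhibition and higher numbers for weaker inhibition), so far. Compound 1 `COc1ccc(/C=C2\CN(C(=S)SCc3cn(Cc4ccccc4Cl)nn3)C/C(=C\c3ccc(OC)cc3)C2=O)cc1` gives 60100 nM, the highest of the three numbers. Compound 2 `Cc1ccc(/C=C2\CN(Cc3cn(Cc4ccccc4F)nn3)C/C(=C\c3ccc(C)cc3)C2=O)cc1` gives 8800 nM, and compound 3 `O=C1/C(=C/c2ccccc2F)CN(Cc2cn(Cc3ccccc3F)nn2)C/C1=C\c1ccccc1F` gives 19700 nM; both of these numbers lie beyond the usual scatter from that of compound 1, so compound 1 is the weakest of the three in this assay. Going by the values given here, compounds 2 and 3 differ from compound 1 in several places at once, so no single step between measured compounds can be read from them.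

Compound 4 `COc1ccc(/C=C2\CN(C(=S)SCc3cn(Cc4ccc(F)cc4)nn3)C/C(=C\c3ccc(OC)cc3)C2=O)cc1` has not yet been measured. It differs from compound 1 in one place: 4-fluorophenyl in place of 2-chlorophenyl on a saturated chain carbon bound to an aromatic nitrogen. Among the compounds with values here, nothing among the measured compounds isolates this change, so the expectation rests on the value of compound 1 alone. The expected step in this assay is small, and compound 4 is expected to end up with a 1.3-fold lower number from compound 1 to compound 4 (0.13 log units; within the scatter), a step that may well stay within the scatter. The estimate for compound 4 in this assay is therefore 45000 nM, with a range from 15000 nM to 120000 nM.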

Compound 4, half-maximal inhibitory concentration: 45600 nM
Compound 4: middle estimate off by 1.0-fold (0.01 log units), on the low side, and the stated range covers the measured number.
By their numbers in this assay, from the lowest: compound 2; then compound 3; then compounds 4 and 1 (each within the scatter of the next).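

In this assay, the exchange of 2-chlorophenyl for 4-fluorophenyl on a saturated chain carbon bound to an aromatic nitrogen gives a 1.3-fold lower number from compound 1 to compound 4 (0.12 log units; within the scatter) and so stays within the scatter. Going by these compounds alone, this is the first single-place step, and it shows that, with the core of compound 1 held fixed, this particular swap of one halogenated phenyl for another leaves the number essentially unmoved. No measurement at hand bears on why the two compounds read alike.

The swap alters both the halogen and its place on the phenyl at once, so the compounds shown do not reveal what either change does alone, and 2-fluorophenyl or 4-chlorophenyl would separate the two. As far as these compounds go, how this position responds to something other than a halogenated phenyl, such as an unsubstituted phenyl or a phenyl carrying an amine or a carboxylic acid, also remains open.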